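Fluorophenyl isomers in the series: expectation for compound 3

The compounds below may be only part of what the source reports. "The series", "measured", "known", "first", "only" and "open" are said of these compounds alone.

Measured in a functional assay on LoVo cells (Homo sapiens) for inhibition, read by MTT assay, with a stated time of 24 h; a lower number here means a stronger inhibitor, a higher number a weaker inhibitor:
- compound 1 `CC1(C)[C@H]2CC[C@]1(C)N(Cc1cn(-c3cccc(F)c3)nn1)C(=O)C2`: 90 nM
- compound 2 `CC1(C)[C@H]2CC[C@]1(C)N(Cc1cn(-c3ccccc3F)nn1)C(=O)C2`: 40 nM

For the measured compounds named here, compound 2 has the lower of the two numbers so far, at 40 nM in this assay. Compound 3 `CC1(C)[C@H]2CC[C@]1(C)N(Cc1cn(-c3ccc(F)cc3)nn1)C(=O)C2` is the next case, with 4-fluorophenyl in place of 2-fluorophenyl on an aromatic nitrogen. Going by the values given here, one measured step bears on this change, since it also swaps one fluorophenyl for another at the same place: a 2.3-fold lower number from compound 1 to compound 2 (0.35 log units; beyond the scatter). Among the compounds with values here, that step is modest and is the only guide, and no measured compound yet carries 4-fluorophenyl. A step of similar modest size towards a higher number is therefore expected in this assay. The expected change is a 1.9-fold higher number from compound 2 to compound 3 (0.27 log units; within the scatter). For compound 3 the estimated value is 75 nM, with an expected range of 25 nM to 220 nM.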

Compound 3, half-maximal inhibitory concentration: 40 nM
Compound 3: the middle estimate sits 1.9-fold (0.27 log units) above what was measured; measured number inside the range.
By their numbers in this assay, from the lowest: compounds 2 and 3 (each within the scatter of the next); then compound 1.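

In this assay, for the compounds shown here, 4-fluorophenyl in place of 2-fluorophenyl on the aromatic nitrogen gives no change at the digits printed from compound 2 to compound 3 (within the scatter), so these two isomers cannot be told apart here. 4-fluorophenyl in place of 3-fluorophenyl gives a 2.3-fold lower number from compound 1 to compound 3 (0.35 log units; beyond the scatter), which shows that the earlier gain is not unique to 2-fluorophenyl and leaves the 3-fluorophenyl isomer as the one with the higher number of the three. No supporting data bear on why the 3-fluorophenyl isomer differs from the other two.

Whether the fluorine contributes at all remains open, as the compounds shown include no unsubstituted phenyl for comparison. It is also unknown whether the same isomer pattern would hold for a chloro, methoxy or amino group on this phenyl ring, or for a difluorophenyl group.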